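Series notes: desmethyl analogue of compound 3

The compounds below may be only part of what the source reports. "The series", "measured", "known", "first", "only" and "open" are said of these compounds alone.

Three compounds carry numbers in an assay on CHO cells for displacement of a labelled ligand from 5-hydroxytryptamine receptor 1D (Homo sapiens); a higher number here means a weaker inhibitor, a lower number a stronger inhibitor. Compound 1 `COC[C@H](NC1CCN(CCCc2c[nH]c3ccc(Cn4cncn4)cc23)CC1)c1ccc(F)cc1` gives 5 nM in this assay. Compound 2 `c1ccc(C2CCCCN2C2CCN(CCCc3c[nH]c4ccc(-n5cnnc5)cc34)CC2)cc1` gives 1.9 nM. Compound 3 `CC(=O)Nc1ccc([C@H](C)NCC2CCN(CCCc3c[nH]c4ccc(-n5cnnc5)cc34)CC2)cc1` gives 0.6 nM, the lowest of the three numbers, and its gap to compound 2 and its gap to compound 1 both lie beyond the scatter. For the measured compounds named here, no two of these three differ in a single place, so no step between measured compounds can be read from them.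

Compound 4 `CC(=O)Nc1ccc(CNCC2CCN(CCCc3c[nH]c4ccc(-n5cnnc5)cc34)CC2)cc1` is not yet measured in this assay. The change from compound 3 to compound 4 is hydrogen in place of methyl on a saturated chain carbon bound to an amine nitrogen and an aromatic carbon. Going by the values given here, nothing among the measured compounds shows what removing this methyl does to the numbers. Compound 3 sits lowest at 0.6 nM, so a move upward is expected rather than downward, of a size around the edge of the scatter; the step is estimated at a 2.5-fold higher number from compound 3 to compound 4 (0.40 log units; beyond the scatter). Compound 4 is expected to give about 1.5 nM in this assay, in a range from 0.5 nM to 4.5 nM.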

Compound 4, half-maximal inhibitory concentration: 4.2 nM
Beside the measured number, compound 4's estimate is 2.8-fold (0.45 log units) below it; low and high end bracket the measured number.
By their numbers in this assay, from the lowest: compound 3; then compound 2; then compounds 4 and 1 (each within the scatter of the next).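

Hydrogen in place of methyl on a saturated chain carbon bound to an amine nitrogen and an aromatic carbon gives, in this assay, a 7.0-fold higher number from compound 3 to compound 4 (0.85 log units; beyond the scatter) as the first step in the series that can be read at a single place. A single carbon at this position therefore matters in this assay: the 1-(4-acetamidophenyl)ethyl group gives the lower number, and 4-acetamidobenzyl gives up much of it. Nothing at hand accounts for the size of this step.

On these data alone, whether an ethyl or hydroxymethyl group on this carbon would take the number lower remains open, as does the effect of the opposite configuration of the methyl-bearing carbon. Whether the same change carries over to the other compounds, such as compound 1, cannot be read from those shown.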